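Methoxy Count on the Carbonyl-Side Aryl Ring

A few compounds are considered here, and "the series" means these few. Any claim that something is new, unique, unknown or untested is made for them only; others in the source may bear on it.

Two compounds of the series have a number in a functional assay on Malme-3M cells (Homo sapiens) for cytotoxicity, read by sulforhodamine B assay, with a stated time of 48 h, tested at 1 uM; on this read-out higher numbers stand for a weaker effect at the one concentration tested and lower numbers for a stronger effect. Compound 1 `COc1ccc(C(=O)/C=C/c2cc(-c3cc(OC)c(OC)c(OC)c3)n[nH]2)cc1OC` gives 106% and stands highest of the two, with compound 2 `COc1cc(-c2cc(/C=C/C(=O)c3ccc(F)c(F)c3)[nH]n2)cc(OC)c1OC` nearest at 97%. For the measured compounds named here, the only step between measured compounds runs a number 9 percentage points lower from compound 1 to compound 2 (within the scatter) and lies within the scatter; it swaps the aryl on the carbonyl carbon, 3,4-difluorophenyl in place of 3,4-dimethoxyphenyl, and the two numbers show no real separation at the one concentration tested.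

Compound 3 `COc1cc(C(=O)/C=C/c2cc(-c3cc(OC)c(OC)c(OC)c3)n[nH]2)cc(OC)c1OC` is unmeasured. Going by the values given here, it differs from compound 1 by methoxy in place of hydrogen on an aromatic carbon on the same aryl that was changed in the one measured step. Among the compounds with values here, that step bears directly on the question and was small, so another change on this ring is expected to stay within the scatter in this assay as well; no other measured step speaks to it. The estimate for compound 3 is therefore 100%, within 85% to 115%, an expected step of a number 6 percentage points lower from compound 1 to compound 3 (within the scatter) that rests on the small size of a number 9 percentage points lower from compound 1 to compound 2 (within the scatter).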

Compound 3, a percentage reported as activity, at one concentration (the size of the read-out at that concentration, not a potency): 89%
For compound 3 the middle estimate is 11 percentage points above the measured one; low and high end bracket the measured number.
By their numbers in this assay, from the lowest: compounds 3, 2 and 1 (each within the scatter of the next, the first and the last beyond it).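

Methoxy in place of hydrogen on an aromatic carbon of the carbonyl-side ring, ortho to a methoxy group, gives a number 17 percentage points lower from compound 1 to compound 3 (beyond the scatter) in this assay, a modest step that shows this position can move the number beyond the scatter, whereas the swap to 3,4-difluorophenyl gave only a number 9 percentage points lower from compound 1 to compound 2 (within the scatter) on the same ring. The change is also not clearly set apart from that swap: compound 2 at 97% and compound 3 at 89% lie within the scatter of each other, so the added methoxy cannot be said to outdo the difluorophenyl ring. No measurement at hand accounts for the step and the read-out, taken at one concentration, gives no potency.

The compounds shown leave open whether the step is specific to methoxy at this carbon, or whether a longer chain such as ethoxy, an amine or a carboxylic acid there would shift the number in the same way. They also leave open whether a hydroxy group in place of one of the methoxy groups on this ring would keep, lose or extend the step.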